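Adding a Methoxy Group to Compound 1

This account rests on a few compounds, and the source may have more. Where it says the series, first, only, none or still open, it means among the compounds named here.

- compound 1 `CCCCCCCCCCCCCCCCCC(=O)OCCCOP(=O)(O)OC[C@H](N)C(=O)O` gives 500 nM
- compound 2 `CCCCCCCCCCCCCCCCCC(=O)CCCCOP(=O)(O)OC[C@H](N)C(=O)O` gives 5000 nM
- compound 3 `CCCCCCCCCCCCCCCCCC(=O)CCCCCOP(=O)(O)OC[C@H](N)C(=O)O` gives > 10000 nM (a limit of the assay, not a number)

These numbers come from a functional assay on cells (Mast cell, Rattus norvegicus, strain Wistar) for activation, read by fluorescence, with a stated time of 15 min; a lower number here means that less compound is needed, a higher number that more compound is needed for the effect. Among the two true numbers, compound 1 stands lowest at 500 nM. Its nearest neighbour is compound 2 at 5000 nM, and that gap lies beyond the usual scatter. Compound 3 reaches only a limit of the assay, so it offers no number for comparison.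

The next compound to be tested is compound 4 `CCCCCCCCCCCCCCCCCC(=O)OC[C@H](COP(=O)(O)OC[C@H](N)C(=O)O)OC`. It keeps the long chain and the shared core of compound 1, and the change is methoxy in place of hydrogen on a saturated chain carbon bound to two saturated chain carbons. This puts methoxy in place of hydrogen on a saturated chain carbon bound to two saturated chain carbons.

Within the data shown here, no measured pair shows this exact change, so the expectation is uncertain. The values of compound 1 at 500 nM and compound 2 at 5000 nM show that numbers in this small set can differ widely, which argues for a broad range. No change beyond the scatter is expected, and the estimated step is a 1.3-fold lower number from compound 1 to compound 4 (0.10 log units; within the scatter). Compound 4 is expected to give about 400 nM, with an estimated range from 100 nM to 2500 nM.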

Compound 4, half-maximal effective concentration: 2000 nM
Compound 4: the middle estimate sits 5.0-fold (0.70 log units) below what was measured; low and high end bracket the measured number.
By their numbers in this assay, from the lowest: compound 1; then compound 4; then compound 2. At a limit, above all of these: compound 3.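

In this assay, putting methoxy in place of hydrogen on a saturated chain carbon bound to two saturated chain carbons gives a 4.0-fold higher number from compound 1 to compound 4 (0.60 log units; beyond the scatter). Among these compounds, the earlier compounds carry no side group on this carbon, so this is the first sign that the carbon does not tolerate every change freely: a group of only 2 heavy atoms moves the number beyond the usual scatter, towards more compound being needed for the effect. The change does not abolish the effect, however, since compound 4 still gives a true number of 2000 nM rather than a limit of the assay, and nothing measured in this set accounts for the size of the step.

As far as these compounds go, what a hydroxyl group, a methyl group or an amine would do in place of the same hydrogen remains open, so this single step cannot show whether the shift belongs to methoxy alone or to any group on this carbon. From the compounds shown here alone, the opposite spatial arrangement of methoxy at this carbon, and a longer ether such as ethoxy, also remain open.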